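Weak Chromone Amides and a Methoxyanilide Variant

A few compounds are considered here, and "the series" means these few. Any claim that something is new, unique, unknown or untested is made for them only; others in the source may bear on it.

Compound 3 `COc1ccc2c(=O)c(/C=C/C(=O)NCc3ccccc3F)coc2c1` is one of three amides built on the same core and tested in a functional assay on A549 cells (Homo sapiens) for inhibition, read by MTT assay, with a stated time of 48 h; on this read-out higher numbers stand for weaker inhibition and lower numbers for stronger inhibition. In this assay compound 3 reaches only > 100000 nM, which is a limit of the assay and not a number. Compound 2 `COc1ccc2c(=O)c(/C=C/C(=O)NCc3ccc(F)cc3)coc2c1` likewise stops at a limit, giving > 100000 nM in this assay. Compound 1 `COc1ccc2c(=O)c(/C=C/C(=O)NCc3cccc(F)c3)coc2c1` is the only one of the three with a readable number, giving 26900 nM in this assay. The two readable steps, an at least 3.7-fold higher number from compound 1 to compound 2 (0.57 log units; beyond the scatter) and an at least 3.7-fold higher number from compound 1 to compound 3 (0.57 log units; beyond the scatter), concern only where the fluorine stands on the benzyl group, and the step from compound 2 to compound 3 cannot be read because of the limit of > 100000 nM in this assay, at which 2 of the 3 values shown sit. Compound 4 `COc1ccc2c(=O)c(/C=C/C(=O)Nc3ccccc3OC)coc2c1` differs from compound 3 by 2-methoxyphenyl in place of 2-fluorobenzyl on an amide-type nitrogen. Among the compounds with values here, none of the measured steps touches this kind of change, so no direction can be drawn from them, and the only anchor is that compound 3 stands at the limit. Compound 4 is therefore expected near 70000 nM, between 20000 nM and 200000 nM. This estimate means an at least 1.4-fold lower number from compound 3 to compound 4 (0.15 log units; that floor lies within the scatter), an expected rather than a measured step.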

Compound 4, half-maximal inhibitory concentration: > 100000 nM
Compound 4: a limit, no number; the forecaster's own chance of this, stated with the estimate: 55%; middle value at least 1.4-fold (0.15 log units) from the limit.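

In this assay compound 4 gives > 100000 nM, a limit of the assay and not a number, so moving from the fluorobenzyl groups to 2-methoxyphenyl on the amide-type nitrogen brings no readable value. Within the data shown here, replacing the 3-fluorobenzyl of the only compound with a readable number gives an at least 3.7-fold higher number from compound 1 to compound 4 (0.57 log units; beyond the scatter), which places 2-methoxyphenyl on the weak side along with the 2-fluorobenzyl and 4-fluorobenzyl amides. The steps from compound 2 and from compound 3 to compound 4 cannot be read, because these compounds all stop at the same ceiling: the limit of > 100000 nM in this assay, at which 3 of the 4 values shown sit.

On these data alone, it stays open whether the fluorine of compound 1 matters at all, or whether an unsubstituted benzyl would read the same. Also open, as far as these compounds go, is whether a 3-chlorobenzyl, a 3-methoxybenzyl or a longer chain ending in 3-fluorophenyl on this nitrogen would give a lower number than compound 1.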